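Fluoro in Place of Chloro: Expected Cytotoxicity of Compound 3

A few compounds are considered here, and "the series" means these few. Any claim that something is new, unique, unknown or untested is made for them only; others in the source may bear on it.

Compound 1, `Cc1ccc2[nH]c(=O)c(CN(Cc3ccco3)C(=O)c3ccc(Br)cc3)cc2c1`: > 55400 nM in an ADME assay on MT2 cells (Homo sapiens) for cytotoxicity, read by XTT assay, with a stated time of 4 days (a higher number here means that more compound is tolerated, a lower number that less compound is tolerated), a limit rather than a number.
Compound 2, `Cc1ccc2[nH]c(=O)c(CN(Cc3ccco3)C(=O)c3ccc(Cl)c(Cl)c3)cc2c1`: 70700 nM in this assay.

Going by the values given here, compound 2 stands as the only compound with an actual number in this assay; the other value shown is a limit. Among the compounds with values here, the one measured step, a step that the limit leaves unreadable from compound 1 to compound 2, cannot be read in size because the limit of > 55400 nM in this assay, at which 1 of the 2 values shown sits, covers compound 1, so it tells nothing about whether changing the halogen pattern on the phenyl ring moves the read-out.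

Compound 3, `Cc1ccc2[nH]c(=O)c(CN(Cc3ccco3)C(=O)c3ccc(F)c(Cl)c3)cc2c1`, has not yet been measured. It differs from compound 2 in one place: fluoro in place of chloro on an aromatic carbon. No measured step bears on this change, since the only step shown is unreadable. With no evidence of movement in either direction, the expectation for compound 3 is a value close to that of compound 2, with no step beyond the usual scatter. Compound 3 is therefore estimated at 70000 nM in this assay, within a range from 35000 nM to 140000 nM, which amounts to an expected step of a 1.0-fold lower number from compound 2 to compound 3 (0.00 log units; within the scatter).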

Compound 3, half-maximal cytotoxic concentration: > 23500 nM
Compound 3 ended at the assay's limit; the forecaster's own chance of this, stated with the estimate: 35%; the middle value is on the limit's open side.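

In this assay compound 3 gives a limit rather than a number, so neither the step from compound 2 to compound 3 nor the step from compound 1 to compound 3 can be read. The compounds shown leave open whether fluoro in place of chloro, or any other change of halogen on the phenyl ring, moves this read-out at all.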